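The source may hold more compounds than are shown below. What is called first, only, known or untested is meant among the compounds shown, and "the series" means these compounds.

In a functional assay on HL-60 cells (Homo sapiens) for antiproliferative activity, read by CCK-8 assay, with a stated time of 72 h (on this read-out lower numbers stand for stronger inhibition and higher numbers for weaker inhibition), two compounds built on the same core have been measured. Compound 1 (`Cc1cc(Nc2cc(N3CCN(C)CC3)nc(Nc3ccc(Cl)cc3)n2)n[nH]1`), which carries a 4-chlorophenyl group, gives 83.4 nM. Compound 2 (`COc1cccc(Nc2nc(Nc3cc(C)[nH]n3)cc(N3CCN(C)CC3)n2)c1`), which carries a 3-methoxyphenyl group, gives 397 nM, the higher of the two numbers and so the weaker inhibition.

Compound 3 (`Cc1cc(Nc2cc(N3CCN(C)CC3)nc(Nc3cccc(Cl)c3)n2)n[nH]1`) differs from compound 2 by chloro in place of methoxy on an aromatic carbon. The group changes from 3-methoxyphenyl to 3-chlorophenyl. Among the compounds with values here, only one measured step bears on this change, a 4.8-fold higher number from compound 1 to compound 2 (0.68 log units; beyond the scatter), and it bears only in part, since it changed both the group and where the group sits. Within the data shown here, no measured pair separates those two changes.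

A lower number than that of compound 2 is nevertheless expected, because chloro is the group held by compound 1 at 83.4 nM. The expected step is a 2.3-fold lower number from compound 2 to compound 3 (0.37 log units; beyond the scatter), a modest one in the direction of stronger inhibition and smaller than the measured step. Compound 3 is estimated at 170 nM, with an expected range of 60 nM to 450 nM.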

Compound 3, half-maximal inhibitory concentration: 131 nM
Compound 3: the middle estimate sits 1.3-fold (0.11 log units) above what was measured; the range from low to high includes it.
By their numbers in this assay, from the lowest: compounds 1 and 3 (each within the scatter of the next); then compound 2.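

Set at one fixed place on the ring, meta to a large group, the exchange of methoxy for chloro can now be read by itself: in this assay it gives a 3.0-fold lower number from compound 2 to compound 3 (0.48 log units; beyond the scatter), and the earlier step could not separate this exchange from a shift in where the group sits. The shift of chloro alone, from 4-chlorophenyl to 3-chlorophenyl, gives a 1.6-fold higher number from compound 1 to compound 3 (0.20 log units; within the scatter), so in this pair the two placements of chloro cannot be told apart on this read-out. The data shown offer no account of why chloro and methoxy differ at this place.

Whether other groups at this place, such as a nitrile, a methyl or an amine, would stay with chloro or fall toward methoxy remains open, since the ring carries only these two groups across the compounds shown. Also open, as far as these compounds go, is how methoxy would behave as 4-methoxyphenyl, which would show whether the exchange of chloro for methoxy carries the same size at the other place.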